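The source may hold more compounds than are shown below. What is called first, only, known or untested is meant among the compounds shown, and "the series" means these compounds.

Measured in a functional assay on HCT-116 cells (Homo sapiens) for inhibition, read by sulforhodamine B assay, with a stated time of 48 h, tested at 50 uM; on this read-out higher numbers stand for more inhibition of growth at the one concentration tested and lower numbers for less inhibition of growth:

- compound 1 `COc1ccccc1/C=C/C(=O)/C=C/c1ccc(OCc2cn(CCCOc3cc(=O)oc4ccccc34)nn2)c(OC)c1`: 53%
- compound 2 `COc1cc(/C=C/C(=O)/C=C/c2cc(OC)c(OC)c(OC)c2)ccc1OCc1cn(CCCCCOc2cc(=O)oc3ccccc23)nn1`: 53%
- compound 3 `COc1cc(/C=C/C(=O)/C=C/c2ccco2)ccc1OCc1cn(CCCCOc2cc(=O)oc3ccccc23)nn1`: 47%

The three compounds share a coumarin-bearing side chain linked through a triazole to a dienone, and differ in the aryl group at the far end of the dienone. Their numbers in this assay sit within the usual scatter of one another: compound 3 is not separated from compound 1 or from compound 2 by more than repeated measurement would give, so no ordering among them is claimed.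

Compound 4 `COc1cc(/C=C/C(=O)/C=C/c2ccccc2)ccc1OCc1cn(CCCCOc2cc(=O)oc3ccccc23)nn1` is the next member and has not been measured. It differs from compound 3 in one place: phenyl in place of furan-2-yl on a double-bonded chain carbon bound to a double-bonded chain carbon. Going by the values given here, no measured pair in this set isolates such a change. Since the aryl variation across compound 1, compound 2 and compound 3 produced no separation beyond the scatter, the step of a number 3 percentage points higher from compound 3 to compound 4 (within the scatter) is expected to be small in either direction and not beyond the scatter. Compound 4 is therefore expected to give 50%, with a range from 38% to 62%.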

Compound 4, percent growth inhibition at one concentration: 34%
Compound 4: middle estimate off by 16 percentage points, on the high side, outside the stated range (below it).
By their numbers in this assay, from the lowest: compound 4; then compounds 3, 1 and 2 (each within the scatter of the next).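

In this assay, phenyl in place of furan-2-yl on a double-bonded chain carbon bound to a double-bonded chain carbon gives a number 13 percentage points lower from compound 3 to compound 4 (beyond the scatter). Going by these compounds alone, this is the first pair that differs in one place, and it shows that the group at this place can by itself move growth inhibition beyond the scatter, which the earlier compounds, differing in more than one place, could not show. No measurement shown here bears on the reason for this step.

Open, as far as these compounds go, is whether thiophen-2-yl or pyridin-2-yl at this place would read like furan-2-yl or like phenyl. Also open, from the compounds shown here alone, is whether the step holds with the longer pentyl-type chain of compound 2 or the shorter chain of compound 1 in place of the chain shared by compound 3 and compound 4.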